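This account rests on a few compounds, and the source may have more. Where it says the series, first, only, none or still open, it means among the compounds named here.

In an ADME assay on PANC-1 cells (Homo sapiens) for inhibition, read by MTT assay (on this read-out lower numbers stand for stronger inhibition of growth and higher numbers for weaker inhibition of growth), compound 1, whose structure is `Cc1nc(C)c(-c2nn(-c3ccc(F)cc3)cc2/C=C/C(=O)c2cc(Cl)cc(Cl)c2O)s1`, gives only a limit of the assay, > 250 ug/mL. Compound 2, with structure `Cc1nc(C)c(-c2nn(-c3ccc(F)cc3)cc2/C=C/C(=O)c2cc(Cl)c(C)cc2O)s1`, likewise gives only a limit, > 250 ug/mL. Among the compounds with values here, the single change between them, a step that the two limits leave unreadable from compound 1 to compound 2, cannot be read in size since both values sit at the same limit (the limit of > 250 ug/mL in this assay, at which 2 of the 2 values shown sit). Within the data shown here, compound 2 therefore stands at the limit, and the only other value shown stands there as well.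

Compound 3, whose structure is `Cc1nc(C)c(-c2nn(-c3ccc(F)cc3)cc2/C=C/C(=O)c2c(O)cc(C)c(Cl)c2C)s1`, differs from compound 2 by methyl in place of hydrogen on an aromatic carbon. Among the measured compounds shown here, no measured step has a readable size, so there is no step of known size to draw on, and the one comparison available is unreadable between two limits. The expectation is therefore no step beyond the scatter, a step that the limit leaves unreadable from compound 2 to compound 3, with the most likely outcome that compound 3 again ends at the limit. The estimate for compound 3 in this assay is 300 ug/mL, within a range from 150 ug/mL to 600 ug/mL.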

Compound 3, concentration for 50% growth inhibition: 35.2 ug/mL
Beside the measured number, compound 3's estimate is 8.5-fold (0.93 log units) above it, and the stated range ends above it.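

In this assay, a single methyl in place of hydrogen on an aromatic carbon, ortho to a chloro group and meta to a hydroxy group, gives an at least 7.1-fold lower number from compound 2 to compound 3 (0.85 log units; beyond the scatter), which means stronger inhibition of growth. The earlier pair could not show that this ring responds to any change at all, since the step between its two members cannot be read, whereas the 3-chloro-6-hydroxy-2,4-dimethylphenyl group in place of 3,5-dichloro-2-hydroxyphenyl on the carbonyl carbon gives an at least 7.1-fold lower number from compound 1 to compound 3 (0.85 log units; beyond the scatter). Both steps are only minimum sizes, and the full gain remains unknown, because compound 1 and compound 2 each give only a limit of the assay: the limit of > 250 ug/mL in this assay, at which 2 of the 3 values shown sit.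

The compounds shown do not tell why this methyl matters, or whether the gain belongs to methyl itself or would also come with a larger or different group at this carbon, such as ethyl, methoxy or an amine. Within the data shown here, they also leave open how far the change carries over to a partner ring with other substituents, since compound 3 is the only compound here with a measured number rather than a limit.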